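Series notes: aminophenyl enone pyrazoles, compound 4 pending

The compounds below may be only part of what the source reports. "The series", "measured", "known", "first", "only" and "open" are said of these compounds alone.

Measured in a functional assay on MOLT-4 cells (Homo sapiens) for cytotoxicity, read by sulforhodamine B assay, with a stated time of 48 h, tested at 1 uM; on this read-out lower numbers stand for a stronger effect and higher numbers for a weaker effect at the one concentration tested:
compound 1 `COc1ccc(-c2cc(/C=C/C(=O)c3ccc(N)cc3)[nH]n2)cc1` gives 80%
compound 2 `COc1cc(-c2cc(/C=C/C(=O)c3ccc(N)cc3)[nH]n2)cc(OC)c1OC` gives 72%
compound 3 `COc1ccc(C(=O)/C=C/c2cc(-c3cc(OC)c(OC)c(OC)c3)n[nH]2)cc1OC` gives 88%

Among the measured compounds shown here, compound 2 has the lowest number of the three; compound 1 sits within the scatter of it, and compound 3 lies beyond it, the single measured step being a number 16 percentage points higher from compound 2 to compound 3 (beyond the scatter).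

Compound 4 `COc1ccc(-c2cc(/C=C/C(=O)c3ccc(N)cc3)[nH]n2)cc1OC` is the next case. Relative to compound 2 the change is hydrogen in place of methoxy on an aromatic carbon. For the measured compounds named here, no measured step covers removal of a methoxy group; the only step available concerns the carbonyl side and does not bear on this change. Compound 1 and compound 2 differ in more than one place and their values sit within the scatter of each other. The expected step is therefore a number 4 percentage points higher from compound 2 to compound 4 (within the scatter), nothing beyond the scatter. The estimate for compound 4 in this assay is 76%, from 62% to 90%.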

Compound 4, a percentage reported as activity, at one concentration (the size of the read-out at that concentration, not a potency): 93%
Compound 4: middle estimate off by 17 percentage points, on the low side; measured number outside the range, above it.
By their numbers in this assay, from the lowest: compounds 2, 1, 3 and 4 (each within the scatter of the next, the first and the last beyond it).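

In this assay the methoxy change on this ring is not a small one, and it does not run in a single direction: a number 21 percentage points higher from compound 2 to compound 4 (beyond the scatter) with hydrogen in place of methoxy, and a number 13 percentage points higher from compound 1 to compound 4 (beyond the scatter) with methoxy in place of hydrogen. Compound 4 therefore reads weaker than both one-place neighbours, so the count of methoxy groups does not track the read-out across these three compounds. Nothing available accounts for this reversal.

Open, from the compounds shown here alone, is whether a hydroxyl or ethoxy group at this carbon would read like methoxy or like hydrogen. Also open, going by these compounds, is whether the same pattern holds with 3,4-dimethoxyphenyl in place of 4-aminophenyl on the carbonyl.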